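Swapping methoxy for trifluoromethyl on a weak inhibitor

The compounds below may be only part of what the source reports. "The series", "measured", "known", "first", "only" and "open" are said of these compounds alone.

Compound 1, `O=c1oc(-c2ccc(I)cc2)nc2ccccc12`, and compound 2, `COc1ccccc1-c1nc2ccccc2c(=O)o1`, share one core and differ only in the group carried on the attached ring. In an assay on isolated protein for inhibition of complement C1r subcomponent (Homo sapiens) (a higher number here means a weaker inhibitor, a lower number a stronger inhibitor), compound 1 gives only a limit of > 62500 nM, not a number. In this assay compound 2 also gives only a limit, > 62500 nM. Both measurements rest at the limit of > 62500 nM in this assay, at which 2 of the 2 values shown sit, so compound 2 stands at the edge of what this assay can report and cannot be ranked against compound 1.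

Compound 3, `O=c1oc(-c2ccccc2C(F)(F)F)nc2ccccc12`, differs from compound 2 by trifluoromethyl in place of methoxy on an aromatic carbon. Among the compounds with values here, no measured pair in this set carries a change of this kind, so its size is untested. Compound 3 is expected to give 100000 nM in this assay, within 30000 nM to 400000 nM, most probably again as a limit only. The expected step that the limit leaves unreadable from compound 2 to compound 3 amounts to no change beyond the usual scatter.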

Compound 3, half-maximal inhibitory concentration: > 62500 nM
Compound 3 ended at the assay's limit (the forecaster's own chance of this, stated with the estimate: 80%); the middle value does not contradict the limit.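

Within the data shown here, compound 2 and compound 3 both rest at a limit in this assay and not at a number, so no step between them can be read: the limit of > 62500 nM in this assay, at which 3 of the 3 values shown sit. The compounds shown leave open whether trifluoromethyl in place of methoxy changes inhibition at all, and which change to the shared core would bring a readable value.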